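Inverting one chain stereocentre of compound 2

A few compounds are considered here, and "the series" means these few. Any claim that something is new, unique, unknown or untested is made for them only; others in the source may bear on it.

Of the compounds shown here, two have been measured. In an assay on isolated protein for binding affinity to prostaglandin F2-alpha receptor (Bos taurus) (on this read-out higher numbers stand for weaker inhibition and lower numbers for stronger inhibition), compound 1 `O=C(O)CCCC/C=C\C[C@H]1[C@@H](O)CO[C@@H]1/C=C/[C@@H](O)COc1cccc(C(F)(F)F)c1` gives 3100 nM. Compound 2 `O=C(O)CC/C=C\CCC[C@H]1[C@@H](O)CO[C@@H]1/C=C/[C@@H](O)COc1cccc(Cl)c1` gives in this assay 147 nM, which is the lowest of the two numbers; its nearest neighbour, compound 1, stands well above it, a gap beyond the scatter. The two compounds differ in several places at once, so this gap is not attributed to any single change.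

Compound 3 `O=C(O)CC/C=C\CCC[C@H]1[C@@H](O)CO[C@@H]1/C=C/[C@H](O)COc1cccc(Cl)c1` has not yet been measured. Compared with compound 2, (the two compounds have the same atoms and bonds and differ only in configuration as drawn: 1 of 6 stereo elements differ; a stereocentre at a saturated chain carbon is drawn R in compound 2 and S in compound 3). Going by the values given here, no pair of measured compounds differs in one place alone, so no measured step guides this change; the expectation rests on compound 2 itself. The step from compound 2 to compound 3 is expected to be a rise in this assay of a 10-fold higher number from compound 2 to compound 3 (1.01 log units; beyond the scatter), beyond the scatter. Compound 3 is accordingly estimated at 1500 nM, within a range from 300 nM to 8000 nM.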

Compound 3, inhibition constant: 820 nM
For compound 3 the middle estimate is 1.8-fold (0.26 log units) above the measured one; the measured number falls inside the stated range.
By their numbers in this assay, from the lowest: compound 2; then compound 3; then compound 1.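

In this assay, going by these compounds alone, inverting the saturated chain carbon from R in the first compound to S in the second gives a 5.6-fold higher number from compound 2 to compound 3 (0.75 log units; beyond the scatter), a modest step but one beyond the scatter. Within the data shown here, this is the first reading of a single change, and it shows that the configuration at this position alone moves the number, with the R form as drawn giving the stronger inhibition. The step can be assigned to this stereocentre and to nothing else because of one fact: the fact that compounds 2 and 3 differ only in the configuration as drawn

Going by these compounds, it remains open how a carbonyl at this chain carbon, which would remove the stereocentre altogether, would read in this assay. Also open, on these data alone, is whether the same inversion gives a step of similar size with trifluoromethyl in place of the chloro group.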